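Trifluoromethyl to Dichlorophenyl on the Urea Nitrogen

The source may hold more compounds than are shown below. What is called first, only, known or untested is meant among the compounds shown, and "the series" means these compounds.

In a functional assay on OVCAR-8 cells (Homo sapiens) for inhibition, read by sulforhodamine B assay, with a stated time of 48 h, tested at 10 uM (on this read-out higher numbers stand for a weaker effect at the one concentration tested and lower numbers for a stronger effect), compound 1 `COc1cc2cc(Oc3ccc(NC(=O)Nc4ccc(C(F)(F)F)cc4)cc3)c(C)nc2cc1OC` gives 37.8%, while compound 2 `COc1cc2cc(Oc3ccc(NC(=O)Nc4cccc(C(F)(F)F)c4)cc3)c(C)nc2cc1OC` gives 8.32%, the lowest of the two numbers, and the shift a number 29.5 percentage points lower from compound 1 to compound 2 (beyond the scatter) lies beyond the scatter. Compound 3 `COc1cc2cc(Oc3ccc(NC(=O)Nc4ccc(Cl)c(Cl)c4)cc3)c(C)nc2cc1OC` differs from compound 2 by 3,4-dichlorophenyl in place of 3-(trifluoromethyl)phenyl on an amide-type nitrogen. Among the compounds with values here, only that one measured step bears on this change, and it concerns a different pair of groups, so it offers little guidance on size or direction. Compound 3 is therefore expected to change little, with a step of a number 3.7 percentage points higher from compound 2 to compound 3 (within the scatter) in this assay. Compound 3 is estimated at 12%, within 3% to 35%.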

Compound 3, a percentage reported as activity, at one concentration (the size of the read-out at that concentration, not a potency): 15%
For compound 3 the middle estimate is 3 percentage points below the measured one; the measured number falls inside the stated range.
By their numbers in this assay, from the lowest: compounds 2 and 3 (each within the scatter of the next); then compound 1.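

In this assay, replacing 3-(trifluoromethyl)phenyl with 3,4-dichlorophenyl gives a number 6.7 percentage points higher from compound 2 to compound 3 (within the scatter), so this position on the amide-type nitrogen keeps its number with no trifluoromethyl group present. Against 4-(trifluoromethyl)phenyl, the same group gives a number 22.8 percentage points lower from compound 1 to compound 3 (beyond the scatter), which leaves compound 1 apart from the other two. No measurement shown here accounts for these numbers. On these data alone, what stays open is whether a methoxy group or a carboxylic acid on this phenyl ring would fit alongside chlorine and trifluoromethyl, and whether a pyridine ring could replace the phenyl ring.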